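Cytotoxicity notes: a dimethyl ketone variant, compound 4

The source may hold more compounds than are shown below. What is called first, only, known or untested is meant among the compounds shown, and "the series" means these compounds.

Compound 1 `Cc1cc(S(N)(=O)=O)ccc1NC(=O)COc1ccc2ccccc2c1C(=O)c1ccccc1` is measured in an ADME assay on C8166 cells (Homo sapiens) for cytotoxicity, read by colorimetric assay and MTT assay (a lower number here means that less compound is tolerated, a higher number that more compound is tolerated), at 33800 nM. Compound 2 `Cc1cccc(C(=O)c2c(OCC(=O)Nc3ccc(S(N)(=O)=O)cc3C)ccc3ccccc23)c1` gives 40400 nM and compound 3 `Cc1cc(S(N)(=O)=O)ccc1NC(=O)COc1ccc2ccccc2c1C(=O)c1cccc(Cl)c1` gives 37400 nM in this assay; compound 1 lies within the scatter of both, as shown by a 1.2-fold higher number from compound 1 to compound 2 (0.08 log units; within the scatter) and a 1.1-fold higher number from compound 1 to compound 3 (0.04 log units; within the scatter), and the remaining step is a 1.1-fold lower number from compound 2 to compound 3 (0.03 log units; within the scatter). Compound 4 `Cc1ccc(C)c(C(=O)c2c(OCC(=O)Nc3ccc(S(N)(=O)=O)cc3C)ccc3ccccc23)c1` is not yet measured; its change from compound 1 is 2,5-dimethylphenyl in place of phenyl on a carbonyl carbon. The step that bears most directly on it is the methyl step, a 1.2-fold higher number from compound 1 to compound 2 (0.08 log units; within the scatter), and the chloro step a 1.1-fold higher number from compound 1 to compound 3 (0.04 log units; within the scatter) is equally flat, so in this assay no movement beyond the scatter is expected. The estimate for compound 4 is 38000 nM, with a range of 20000 nM to 72000 nM. The step expected from this estimate is a 1.1-fold higher number from compound 1 to compound 4 (0.05 log units; within the scatter).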

Compound 4, half-maximal cytotoxic concentration: 47500 nM
The estimate for compound 4 lay 1.3-fold (0.10 log units) below the measured number; the measured number falls inside the stated range.
By their numbers in this assay, from the lowest: compounds 1, 3, 2 and 4 (each within the scatter of the next).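

In this assay the 2,5-dimethylphenyl group on the carbonyl carbon stays within the scatter of the phenyl group (a 1.4-fold higher number from compound 1 to compound 4 (0.15 log units; within the scatter)), so carrying two methyl groups moves this position no further than the scatter allows. The same holds against the single methyl (a 1.2-fold higher number from compound 2 to compound 4 (0.07 log units; within the scatter)) and the 3-chlorophenyl group (a 1.3-fold higher number from compound 3 to compound 4 (0.10 log units; within the scatter)). Nothing measured gives a reason for these flat steps. On these data alone, whether an amine or a carboxylic acid on this ring would give a step beyond the scatter stays open.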